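This account rests on a few compounds, and the source may have more. Where it says the series, first, only, none or still open, it means among the compounds named here.

Measured so far in a functional assay on A549 cells (Homo sapiens) for antiproliferative activity, read by MTT assay, with a stated time of 24 h; on this read-out higher numbers stand for weaker inhibition and lower numbers for stronger inhibition:
compound 1 `O=c1[nH]cc(S(=O)(=O)Nc2ccccc2-c2cn(-c3ccc(F)cc3)nn2)c(=O)[nH]1`, 6390 nM
compound 2 `O=c1[nH]cc(S(=O)(=O)Nc2ccc(-c3cn(-c4ccccc4)nn3)cc2)c(=O)[nH]1`, 7170 nM
compound 3 `Cc1ccccc1-n1cc(-c2ccc(NS(=O)(=O)c3c[nH]c(=O)[nH]c3=O)cc2)nn1`, 3130 nM

Compound 3 gives the lowest number of the three; compound 1 and compound 2 both sit higher. For the measured compounds named here, the only single change among the measured compounds is a 2.3-fold lower number from compound 2 to compound 3 (0.36 log units; beyond the scatter), a modest step. Compound 4 `Cc1cccc(-n2cc(-c3ccc(NS(=O)(=O)c4c[nH]c(=O)[nH]c4=O)cc3)nn2)c1` is built from compound 3 by 3-methylphenyl in place of 2-methylphenyl on an aromatic nitrogen. Going by the values given here, no measured pair shows this kind of change in the methylphenyl group, so the step from compound 2 to compound 3 is the nearest guide, and it bears only loosely, since both compound 3 and compound 4 carry a methyl. For compound 4 the expected change is a 1.1-fold higher number from compound 3 to compound 4 (0.05 log units; within the scatter), likely within the scatter. The estimate for compound 4 is 3500 nM, in the range 1500 nM to 8000 nM.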

Compound 4, half-maximal inhibitory concentration: 6960 nM
Beside the measured number, compound 4's estimate is 2.0-fold (0.30 log units) below it; the measured number falls inside the stated range.
By their numbers in this assay, from the lowest: compound 3; then compounds 1, 4 and 2 (each within the scatter of the next).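

In this assay, moving the methyl so that 3-methylphenyl replaces 2-methylphenyl on the aromatic nitrogen gives a 2.2-fold higher number from compound 3 to compound 4 (0.35 log units; beyond the scatter) with no atom gained or lost. Adding the methyl in the 3-methylphenyl form gives a 1.0-fold lower number from compound 2 to compound 4 (0.01 log units; within the scatter) and so no readable gain, which means that among these compounds only the 2-methylphenyl form stands apart from plain phenyl. Nothing here explains why the two placements differ. From the compounds shown here alone, whether an ethyl, a methoxy or a chlorine in these two placements would behave like the methyl stays open.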